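This account rests on a few compounds, and the source may have more. Where it says the series, first, only, none or still open, it means among the compounds named here.

The measured compounds:

Compound 1, `CC1CCCCC1N(CCCCCCN1C[C@H](O)[C@@H](O)[C@H](O)[C@H]1CO)C(=O)OC(C)(C)C`: in an ADME assay on MDBK cells (Bos taurus) for cytotoxicity, read by MTT assay (a higher number here means that more compound is tolerated, a lower number that less compound is tolerated), compound 1 gives 250000 nM.
Compound 2, `CC1CCCCC1N(CCCCCCN1C[C@H](O)[C@@H](O)[C@H](O)[C@H]1CO)C(=O)C(C)(C)C`: in this assay compound 2 is reported only as a limit, > 500000 nM.
Compound 3, `CC(=O)N(CCCCCCN1C[C@H](O)[C@@H](O)[C@H](O)[C@H]1CO)c1cc(F)ccc1F`: in this assay compound 3 is likewise reported only as a limit, > 500000 nM.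

Compound 2 thus has no number of its own in this assay, only a limit, and the limit of > 500000 nM in this assay, at which 2 of the 3 values shown sit, shows that most of the set sits there as well. Going by the values given here, the single measured step, an at least 2.0-fold higher number from compound 1 to compound 2 (0.30 log units; that floor lies within the scatter), concerns a different exchange on the carbonyl carbon, and its floor lies within the scatter, so it sets no direction for any further change. Compound 4, `CC(C)(C)C(=O)N(CCCCCCN1C[C@H](O)[C@@H](O)[C@H](O)[C@H]1CO)C1CCCCCC1`, differs from compound 2 by cycloheptyl in place of 2-methylcyclohexyl on an amide-type nitrogen. No measured step touches a change on the amide-type nitrogen, so this ring exchange has no precedent among the compounds shown. With nothing pointing either way, the step from compound 2 to compound 4 in this assay is expected to stay within the scatter, a number no higher from compound 2 to compound 4 (the limit leaves the size open). Compound 4 is therefore estimated at 500000 nM, with a range from 250000 nM to 1000000 nM, and most probably will again be reported only as a limit.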

Compound 4, half-maximal cytotoxic concentration: > 500000 nM
Compound 4 gave a limit, no number (the forecaster's own chance of this, stated with the estimate: 70%); the middle value lies on the limit itself.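

In this assay, compound 2 and compound 4 are both reported only as limits, so no step can be read between them, and the exchange of 2-methylcyclohexyl for cycloheptyl has no readable size. The compounds shown leave open where the actual values of compound 2 and compound 4 lie, and whether this exchange on the amide-type nitrogen changes them at all.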